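The source may hold more compounds than are shown below. What is called first, only, known or untested is meant among the compounds shown, and "the series" means these compounds.

Measured in a functional assay on PANC-1 cells (Homo sapiens) for cytotoxicity, read by WST assay, with a stated time of 24 h; a higher number here means a weaker inhibitor, a lower number a stronger inhibitor:
- Compound 1 `O=C(CCCCCCCCCCc1ccccc1)N1CCCCC1`: > 100000 nM (a limit of the assay, not a number)
- Compound 2 `O=C(CCCCCCCCc1ccc(F)cc1)N1CCCCC1`: 99800 nM

For the measured compounds named here, compound 2, at 99800 nM, holds the only number so far. Compound 1 stands at the limit of > 100000 nM in this assay, at which 1 of the 2 values shown sits.

Compound 3 `O=C(CCCCCCCCc1ccccc1Cl)N1CCCCC1` is the next step, with 2-chlorophenyl in place of 4-fluorophenyl on a saturated chain carbon, eight bonds along the chain from a carbonyl carbon.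

Going by the values given here, the one measured step is a number no higher from compound 1 to compound 2 (the limit leaves the size open). It concerns 4-fluorophenyl in place of phenethyl, so it is not the same change, and its size cannot be read.

Resting on compound 2 at 99800 nM alone, the expected 1.2-fold lower number from compound 2 to compound 3 (0.10 log units; within the scatter) in this assay stays within the usual scatter, with no direction favoured. A further limit reading is also possible.

For compound 3 the estimated value is 80000 nM, with an expected range of 30000 nM to 150000 nM.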

Compound 3, half-maximal inhibitory concentration: > 100000 nM
Compound 3 was reported as a limit (the forecaster's own chance of this, stated with the estimate: 40%); middle value at least 1.2-fold (0.09 log units) away from the limit.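

In this assay, 2-chlorophenyl in place of 4-fluorophenyl on a saturated chain carbon, eight bonds along the chain from a carbonyl carbon, gives a number no lower from compound 2 to compound 3 (the limit leaves the size open). Compound 3 gives > 100000 nM, which is a limit of the assay and not a number. This exchange of one substituted phenyl group for the other therefore gives no stronger reading at this position, and most of the series now rests on a limit: the limit of > 100000 nM in this assay, at which 2 of the 3 values shown sit.

The sizes of the steps from compound 2 to compound 3 and from compound 1 to compound 3 cannot be read. From the compounds shown here alone, it remains open whether an amine or a carboxylic acid in place of the substituted phenyl group at this chain position would give a reading clear of the limit.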